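Trading Chloro for Fluoro on Compound 3

The source may report more compounds than this note shows. Statements on the series, on what has been measured and on what is new or still open speak of the compounds shown alone.

Of the compounds shown here, three that share most of their structure have been tested in a functional assay on the whole organism for antagonist activity, with Rattus norvegicus as the target; on this read-out higher numbers stand for an effect only at larger amounts of compound and lower numbers for an effect already at smaller amounts. Compound 1 `c1ccc2c(c1)CC2CN1CCN(c2cccc3c2OCCO3)CC1` gives 0.67 mg/kg, compound 2 `c1ccc2c(c1)CCCC2CCN1CCN(c2cccc3c2OCCO3)CC1` gives 0.4 mg/kg and compound 3 `Clc1cccc2c1CC2CN1CCN(c2cccc3c2OCCO3)CC1` gives 0.8 mg/kg. Repeated measurements of this kind naturally vary, and the gaps between compound 3 and the other two stay within that variation, so compound 3 stands level with both.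

Compound 4 `Fc1cccc2c1CC2CN1CCN(c2cccc3c2OCCO3)CC1` has not been measured yet. It differs from compound 3 by fluoro in place of chloro on an aromatic carbon.

Among the compounds with values here, no measured pair shows this exact exchange. The closest evidence is the pair that differs by chloro in place of hydrogen on an aromatic carbon, which gave a 1.2-fold higher number from compound 1 to compound 3 (0.08 log units; within the scatter). Adding the chloro of compound 3 to compound 1 therefore made no clear difference, and nothing in the data suggests that replacing it with fluoro should matter more. The expected change is a 1.1-fold lower number from compound 3 to compound 4 (0.06 log units; within the scatter), which means no real shift beyond the scatter.

For compound 4, the estimated value in this assay is 0.7 mg/kg, with an expected range from 0.35 mg/kg to 1.4 mg/kg.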

Compound 4, dose for 50% inhibition: 2.51 mg/kg
Compound 4: the middle estimate sits 3.6-fold (0.55 log units) below what was measured, outside the stated range (above it).
By their numbers in this assay, from the lowest: compounds 2, 1 and 3 (each within the scatter of the next); then compound 4.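

In this assay, this place on the aromatic ring proves sensitive to which halogen sits there: fluoro in place of chloro gives a 3.1-fold higher number from compound 3 to compound 4 (0.50 log units; beyond the scatter) and so needs a larger dose for the same effect. Fluoro also stands apart from hydrogen, with a 3.7-fold higher number from compound 1 to compound 4 (0.57 log units; beyond the scatter) as its step, whereas a 1.2-fold higher number from compound 1 to compound 3 (0.08 log units; within the scatter) had left chloro level with hydrogen. The quiet result for chloro therefore said little about fluoro, and two halogens on the same aromatic carbon cannot be treated as interchangeable in this series.

No measurement available here accounts for the gap between chloro and fluoro. The compounds shown also leave open whether fluoro is the exception at this place or one point on a wider spread, which bromo, methyl or methoxy on the same aromatic carbon could help to settle, and whether the same exchange would have a similar effect on another core, such as that of compound 2.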